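Homologation of the amine chain on the chloro congener

The source may report more compounds than this note shows. Statements on the series, on what has been measured and on what is new or still open speak of the compounds shown alone.

Measured so far:
compound 1, `CN(C)CCN1CCN(CC(=O)Nc2ccc(-c3nc4cc(F)ccc4o3)cc2)CC1`: 8190 nM
compound 2, `CN(C)CCCN1CCN(CC(=O)Nc2ccc(-c3nc4ccccc4o3)cc2)CC1`: 10600 nM
compound 3, `CN(C)CCN1CCN(CC(=O)Nc2ccc(-c3nc4cc(Cl)ccc4o3)cc2)CC1`: 4470 nM

In a functional assay on HT-29 cells (Homo sapiens) for cytotoxicity, read by MTT assay, with a stated time of 24 h (a lower number here means a stronger inhibitor, a higher number a weaker inhibitor), compound 3 holds the lowest of the three numbers. Its neighbour is compound 1, reached by a 1.8-fold lower number from compound 1 to compound 3 (0.26 log units; within the scatter); compound 2 lies furthest off, its number beyond the scatter from that of compound 3. Going by the values given here, compound 2 differs from compound 1 in two places at once, so no single step is isolated between them; their values stand close together.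

Compound 4, `CN(C)CCCN1CCN(CC(=O)Nc2ccc(-c3nc4cc(Cl)ccc4o3)cc2)CC1`, has not been measured. It differs from compound 3 by (dimethylamino)methyl in place of dimethylamino on a saturated chain carbon, two bonds along the chain from an amine nitrogen in a ring. No measured step in this series changes that chain alone, so nothing shown here isolates the effect of the change. What compound 1 and compound 2 show together, with the substituent also changed, gives no sign of a large shift. The step from compound 3 to compound 4 is therefore expected to be a 1.1-fold higher number from compound 3 to compound 4 (0.05 log units; within the scatter), within the scatter. For compound 4 in this assay the expected value is 5000 nM, with a range from 2500 nM to 10000 nM.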

Compound 4, half-maximal inhibitory concentration: 1640 nM
Estimate against measurement, compound 4: 3.0-fold (0.48 log units) above; the measured number lies below the stated range.
By their numbers in this assay, from the lowest: compound 4; then compounds 3, 1 and 2 (each within the scatter of the next, the first and the last beyond it).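

In this assay, going by these compounds alone, the step of a 2.7-fold lower number from compound 3 to compound 4 (0.44 log units; beyond the scatter) comes with (dimethylamino)methyl in place of dimethylamino on a saturated chain carbon; this is the first change to that chain alone, and it lies beyond the scatter. The step of a 6.5-fold lower number from compound 2 to compound 4 (0.81 log units; beyond the scatter) comes with a chloro group that compound 2 lacks, with the longer chain held fixed, so each of the two places now shows its own step, whereas compound 1 and compound 2 differ in both at once and stand close together. Nothing at hand gives a cause for either step.

On these data alone, whether the chain effect carries over to the fluoro or unsubstituted cores remains open, as only the chloro pair isolates it. A still longer chain, or a pyrrolidine at the chain end, would show whether the number keeps falling.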